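A Phenyl for Methyl on the Far Ring

The source may report more compounds than this note shows. Statements on the series, on what has been measured and on what is new or still open speak of the compounds shown alone.

In a functional assay on RS4-11 cells (Homo sapiens) for inhibition, read by CCK-8 assay, with a stated time of 48 h, tested at 20 uM (on this read-out lower numbers stand for less inhibition of growth and higher numbers for more inhibition of growth at the one concentration tested), compound 3 `Cc1ccc(S(=O)(=O)Oc2cccc(/C=C(\C#N)C(=O)Nc3nnc(C)s3)c2)cc1` gives 28%, within the scatter of compound 2 `Cc1nnc(NC(=O)/C(C#N)=C/c2cccc(OS(C)(=O)=O)c2)s1` at 33%, while compound 1 `COc1ccc(S(=O)(=O)Oc2ccccc2/C=C(\C#N)C(=O)Nc2nnc(-c3cccs3)s2)cc1` stands well higher at 76%. Compound 4 `Cc1ccc(S(=O)(=O)Oc2cccc(/C=C(\C#N)C(=O)Nc3nnc(-c4ccccc4)s3)c2)cc1` differs from compound 3 by phenyl in place of methyl on an aromatic carbon. Going by the values given here, the one measured step, a number 5 percentage points lower from compound 2 to compound 3 (within the scatter), concerns a sulfonyl sulfur and so says little about this change. Compound 1, at 76%, also carries a ring at this place, but it differs from compound 3 elsewhere too, so it offers only loose support for a rise in this assay. The expected change is a number 22 percentage points higher from compound 3 to compound 4 (beyond the scatter). Compound 4 is estimated at 50%, with an expected range of 30% to 72%.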

Compound 4, percent growth inhibition at one concentration: 35%
The estimate for compound 4 lay 15 percentage points above the measured number; the measured number falls inside the stated range.
By their numbers in this assay, from the lowest: compounds 3, 2 and 4 (each within the scatter of the next); then compound 1.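

In this assay, phenyl in place of methyl on this aromatic carbon of the five-membered ring gives a number 7 percentage points higher from compound 3 to compound 4 (within the scatter) and so does not separate the two compounds. At this position, in the setting of the shared core, a six-membered aromatic ring of carbon only is thus no clear gain over methyl. Nothing available here explains this outcome.

As far as these compounds go, whether an amine, a carboxylic acid or a longer chain on this same carbon would move the number beyond the scatter remains open.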